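Chloro on the pyridyl ring of vinyl sulfones

The compounds below may be only part of what the source reports. "The series", "measured", "known", "first", "only" and "open" are said of these compounds alone.

The series shares a methoxyphenyl vinyl sulfone core carrying a pyridyl ring on the chain. Compound 1 `COc1ccc(S(=O)(=O)/C=C/c2ccccn2)cc1` is the parent with a pyridin-2-yl group. In an ADME assay on BV-2 cells (Mus musculus) for cytotoxicity, with a stated time of 24 h, tested at 50 uM (on this read-out lower numbers stand for a stronger effect and higher numbers for a weaker effect at the one concentration tested), compound 1 gives 100%. Compound 2 `COc1ccc(S(=O)(=O)/C=C/c2cccc(Cl)n2)cc1` carries a chloro group on that ring; in this assay compound 2 gives 85%. Compound 3 `COc1ccc(S(=O)(=O)/C=C/c2cccnc2)cc1` carries the pyridin-3-yl group instead; in this assay compound 3 gives 85.8%. The two cores differ as follows: pyridin-3-yl in place of pyridin-2-yl on a double-bonded chain carbon bound to a double-bonded chain carbon, and the step is a number 14.2 percentage points lower from compound 1 to compound 3 (beyond the scatter). Compound 2 and compound 3 lie within the scatter of each other.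

The change from compound 1 to compound 2 is chloro in place of hydrogen on an aromatic carbon, and it made the step of a number 15 percentage points lower from compound 1 to compound 2 (beyond the scatter). The change from compound 3 to compound 4 `COc1ccc(S(=O)(=O)/C=C/c2cccnc2Cl)cc1` is chloro in place of hydrogen on an aromatic carbon. The place lines are not identical: in compound 2 the chloro sits meta to a large group, in compound 4 it sits ortho to a large group, so this is the same kind of change on a different core rather than the same change. For the measured compounds named here, only one earlier instance exists, and it occurs on the other core, so its transfer is uncertain.

Going by the values given here, for compound 4 in this assay a step of a number 10.8 percentage points lower from compound 3 to compound 4 (beyond the scatter) is expected, resting on the single precedent a number 15 percentage points lower from compound 1 to compound 2 (beyond the scatter) and taken somewhat smaller given the change of place. Compound 4 is estimated at 75%, between 55% and 95%.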

Compound 4, a percentage reported as activity, at one concentration (the size of the read-out at that concentration, not a potency): 76.3%
Estimate against measurement, compound 4: 1.3 percentage points below; low and high end bracket the measured number.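

On the core of compound 3, chloro in place of hydrogen on an aromatic carbon, next to the ring nitrogen and ortho to a large group, gives in this assay a number 9.5 percentage points lower from compound 3 to compound 4 (within the scatter), so on this core the change cannot be told apart from the usual spread of repeated measurements. Set beside the instance on the core of compound 1, the two steps do not differ, and within this pair of cores the change can be carried over without a detectable loss of agreement: the same change on two cores in this assay, a number 15 percentage points lower (beyond the scatter) from compound 1 to compound 2 and a number 9.5 percentage points lower (within the scatter) from compound 3 to compound 4, 5.5 percentage points apart, within the scatter of two such steps This does not establish a fixed size for the change, as it rests on two pairs only, the chloro stands in a different place on each core, one step lies beyond the scatter and the other within it, and a gap within the scatter does not show that the two steps are equal.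

The compounds shown leave open how a larger halogen such as bromo, an amine or a carboxylic acid on the pyridyl ring would read in this assay. They also leave open whether the small differences seen here persist at other concentrations or exposure times.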